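Swapping 3,5-dimethoxyphenyl for 4-chloro-2-methylphenyl

The source may hold more compounds than are shown below. What is called first, only, known or untested is meant among the compounds shown, and "the series" means these compounds.

In a functional assay on A549 cells (Homo sapiens) for antiproliferative activity, read by spectrophotometry, with a stated time of 2 days (a lower number here means a stronger inhibitor of growth, a higher number a weaker inhibitor of growth), compound 1 `COc1ccc(C(F)(F)F)cc1Nc1ncc(C(F)(F)F)c(N2Cc3cccc(N(C)S(C)(=O)=O)c3C2)n1` gives > 30000 nM, which is a limit of the assay. Compound 2 `COc1cc(Nc2ncc(C(F)(F)F)c(N3Cc4cccc(N(C)S(C)(=O)=O)c4C3)n2)c(OC)cc1Cl` gives 7300 nM, and compound 3 `COc1cc(Nc2ncc(C(F)(F)F)c(N3Cc4cccc(N(C)S(C)(=O)=O)c4C3)n2)cc(OC)c1` gives 24800 nM, the higher of the two actual numbers. Compound 4 `Cc1cc(Cl)ccc1Nc1ncc(C(F)(F)F)c(N2Cc3cccc(N(C)S(C)(=O)=O)c3C2)n1` differs from compound 3 by 4-chloro-2-methylphenyl in place of 3,5-dimethoxyphenyl on a nitrogen on an aromatic ring, with 4-chloro-2-methylphenyl in place of 3,5-dimethoxyphenyl on a nitrogen on an aromatic ring. The steps involving 4-chloro-2,5-dimethoxyphenyl, the measured group nearest in name to the incoming one, bear most on this change, namely a 3.4-fold higher number from compound 2 to compound 3 (0.53 log units; beyond the scatter) and an at least 4.1-fold lower number from compound 1 to compound 2 (0.61 log units; beyond the scatter). A modest move to a lower number is therefore expected in this assay. The estimated change is a 2.3-fold lower number from compound 3 to compound 4 (0.35 log units; beyond the scatter). For compound 4 the expected value is 11000 nM, with an estimated range of 4000 nM to 30000 nM.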

Compound 4, concentration for 50% growth inhibition: 25500 nM
Beside the measured number, compound 4's estimate is 2.3-fold (0.37 log units) below it; measured number inside the range.
By their numbers in this assay, from the lowest: compound 2; then compounds 3 and 4 (each within the scatter of the next). At a limit, above all of these: compound 1.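

In this assay, 4-chloro-2-methylphenyl in place of 3,5-dimethoxyphenyl on a nitrogen on an aromatic ring gives a 1.0-fold higher number from compound 3 to compound 4 (0.01 log units; within the scatter), so these two groups are not separated here. Chlorine in the group is not enough to reach the number of compound 2, which stays apart, with a 3.5-fold higher number from compound 2 to compound 4 (0.54 log units; beyond the scatter). Compound 1 sits at a limit of the assay: the limit of > 30000 nM in this assay, at which 1 of the 4 values shown sits. The remaining step gives only an at least 1.1-fold lower number from compound 1 to compound 4 (0.07 log units; that floor lies within the scatter), so it shows no separation.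

As far as these compounds go, it remains open whether a methoxy group added to the 4-chloro-2-methylphenyl ring would restore the number of compound 2. Also open, from the compounds shown here alone, is how an amine or a carboxylic acid on this ring would read.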